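Shifting a methoxy group on a sulfonamide-benzamide pyrazole series

The source may report more compounds than this note shows. Statements on the series, on what has been measured and on what is new or still open speak of the compounds shown alone.

Measured compounds:
compound 1, `COc1ccc(-n2cc(NC(=O)c3cccc(NS(=O)(=O)c4ccc(Cl)cc4)c3)cn2)cc1`, 15200 nM
compound 2, `COc1cccc(-n2cc(NC(=O)c3cccc(NS(=O)(=O)c4ccc(Cl)cc4)c3)cn2)c1`, 19600 nM
compound 3, `COc1ccc(-n2cc(NC(=O)c3ccc(NS(=O)(=O)c4ccccc4)cc3)cn2)cc1`, 57300 nM

These three compounds were tested in a functional assay on HepG2 cells (Homo sapiens) for inhibition, read by MTT assay, with a stated time of 48 h; a lower number here means a stronger inhibitor, a higher number a weaker inhibitor. Compound 1 and compound 2 share one core, compound 3 stands on another; the difference between the two cores is not broken down here. Compound 3 gives the highest number of the three, its step to compound 2 and to compound 1 both lying beyond the scatter.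

The change from compound 1 to compound 2, (3-methoxyphenyl in place of 4-methoxyphenyl on an aromatic nitrogen), gave a 1.3-fold higher number from compound 1 to compound 2 (0.11 log units; within the scatter). Compound 4, `COc1cccc(-n2cc(NC(=O)c3ccc(NS(=O)(=O)c4ccccc4)cc3)cn2)c1`, is not yet measured; it arises from compound 3 by the same change, (3-methoxyphenyl in place of 4-methoxyphenyl on an aromatic nitrogen), at the same place. Because the step of a 1.3-fold higher number from compound 1 to compound 2 (0.11 log units; within the scatter) was within the scatter, compound 4 is expected to give about a 1.3-fold higher number from compound 3 to compound 4 (0.11 log units; within the scatter), with an estimated value of 74000 nM, between 35000 nM and 160000 nM.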

Compound 4, half-maximal inhibitory concentration: 64200 nM
Beside the measured number, compound 4's estimate is 1.2-fold (0.06 log units) above it; low and high end bracket the measured number.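

In this assay the shift of the methoxy group gave a 1.1-fold higher number from compound 3 to compound 4 (0.05 log units; within the scatter) and so, on the second core as on the first, moving from 4-methoxyphenyl to 3-methoxyphenyl on the aromatic nitrogen stayed within the scatter. The two steps agree in size: the same change on two cores in this assay, a 1.3-fold higher number (0.11 log units; within the scatter) from compound 1 to compound 2 and a 1.1-fold higher number (0.05 log units; within the scatter) from compound 3 to compound 4, 1.2-fold (0.06 log units) apart, within the scatter of two such steps. This shows that the change carries from one core to the other in this assay without a readable effect on either, but it does not show how the change would read on any further core or in any other assay.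

The compounds shown leave open what a different group at this place would do, such as an amine, a carboxylic acid or a longer chain in place of the methoxy group. They also leave open which part of the difference between the two cores matters.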